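This account rests on a few compounds, and the source may have more. Where it says the series, first, only, none or still open, it means among the compounds named here.

Compound 3 `CCCCCSc1nc(N)c2nc(O)n(Cc3ccccc3)c2n1` is the member of this small set with the highest number in a functional assay on the whole organism for activation, with Mus musculus as the target (a higher number here means that more compound is needed for the effect, a lower number that less compound is needed), giving 1 mg/kg. Compound 1 `CCCCCOc1nc(N)c2nc(O)n(Cc3ccccc3)c2n1` gives 0.3 mg/kg, and compound 2 `CCSc1nc(N)c2nc(O)n(Cc3ccccc3)c2n1` gives 0.1 mg/kg. The steps among them are all beyond the scatter: a 10-fold higher number from compound 2 to compound 3 (1.00 log units; beyond the scatter), and a 3.3-fold higher number from compound 1 to compound 3 (0.52 log units; beyond the scatter), while a 3.0-fold lower number from compound 1 to compound 2 (0.48 log units; beyond the scatter).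

Compound 4 `CCCCNc1nc(N)c2nc(O)n(Cc3ccccc3)c2n1` differs from compound 3 in a single place: butylamino in place of pentylsulfanyl on an aromatic carbon. Within the data shown here, two measured steps bear on this. The step from compound 2 to compound 3 shows that a longer chain on this substituent raised the number, and the step from compound 1 to compound 3 shows that the sulfur-linked pentyl chain carries a higher number than the oxygen-linked one. The change to compound 4 both shortens the chain and exchanges the sulfur linker, so a lower number is expected, of a modest size, a 3.3-fold lower number from compound 3 to compound 4 (0.52 log units; beyond the scatter). Compound 4 is therefore estimated at 0.3 mg/kg, with a range from 0.1 mg/kg to 1 mg/kg.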

Compound 4, minimum effective dose: 0.1 mg/kg
Compound 4: the middle estimate sits 3.0-fold (0.48 log units) above what was measured; the range from low to high includes it.
By their numbers in this assay, from the lowest: compounds 2 and 4 (each within the scatter of the next); then compound 1; then compound 3.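

In this assay, butylamino on this aromatic carbon between two ring nitrogen atoms gives a 10-fold lower number from compound 3 to compound 4 (1.00 log units; beyond the scatter) and a 3.0-fold lower number from compound 1 to compound 4 (0.48 log units; beyond the scatter), so a nitrogen-linked chain here does not carry the high number of the pentyl chains linked through sulfur or oxygen. Set against the short sulfur-linked chain, it gives no change at the digits printed from compound 2 to compound 4 (within the scatter), which shows that a chain longer than ethyl can keep the low number when it is linked through nitrogen, and compound 4 thus goes against the rise seen with chain length between compound 2 and compound 3. No measurement here accounts for these differences.

Going by these compounds, each step to compound 4 changes the linking atom and the chain together, so the share of each remains open. Ethylamino, pentylamino or butylsulfanyl at this position would separate the two, and whether a branched chain or a ring-bearing amine fits the same trend is also unsettled.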